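Benzyloxy for Cyano: Expected Stability of Compound 3

A few compounds are considered here, and "the series" means these few. Any claim that something is new, unique, unknown or untested is made for them only; others in the source may bear on it.

Measured so far:
- compound 1, `COc1cc(OCc2cccc(Sc3ccccc3)c2)c2cc(-c3cn4nc(OC)sc4n3)oc2c1`: 45%
- compound 2, `COc1cc(OCc2cccc(C#N)c2)c2cc(-c3cn4nc(OC)sc4n3)oc2c1`: "not determined" (no result reported)

Compound 1 was tested in an ADME assay on microsomes from liver (Rattus norvegicus) for metabolic stability, with a stated time of 10 min (a higher number here means that more of the compound is left, a lower number that less of the compound is left), and gives 45%. For compound 2, `COc1cc(OCc2cccc(C#N)c2)c2cc(-c3cn4nc(OC)sc4n3)oc2c1`, the outcome in this assay is "not determined" (no result reported), so there is no number for where it stands; the only measured value among these compounds is the one for compound 1.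

Compound 3, `COc1cc(OCc2cccc(OCc3ccccc3)c2)c2cc(-c3cn4nc(OC)sc4n3)oc2c1`, differs from compound 2 in one place: benzyloxy in place of cyano on an aromatic carbon. Within the data shown here, because compound 2 has no value in this assay, the size and direction of the step from compound 2 to compound 3 cannot be read from the data; no step is known here at all. Among the measured compounds shown here, the only anchor is compound 1, which carries a large group in place of the cyano of compound 2. In this assay compound 1 gives 45%.

Resting on that single value, compound 3 is expected to show a stability in this assay of about 35%, with a likely range from 12% to 60%.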

Compound 3, percent of the compound remaining: 76%
For compound 3 the middle estimate is 41 percentage points below the measured one, outside the stated range (above it).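

Replacing phenylsulfanyl with benzyloxy on this aromatic carbon gives a number 31 percentage points higher from compound 1 to compound 3 (beyond the scatter) in this assay and so makes a clear difference at this position. Both groups are large and both end in a six-membered aromatic ring of carbon only, so at this position the result does not follow from the presence of a large aromatic group alone: the identity of the group, including how its ring is attached, matters among these two compounds. No available information explains the difference between the two groups.

On these data alone, the step from compound 2 to compound 3 cannot be read, since compound 2 has no value in this assay and the effect of exchanging cyano for a large group therefore stays unknown. The compounds shown also leave open how other groups would behave at this position, such as an amine, a carboxylic acid or a simple methoxy group, and whether the higher number seen with benzyloxy would hold on a different core.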